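The source may hold more compounds than are shown below. What is called first, only, known or untested is meant among the compounds shown, and "the series" means these compounds.

Measured compounds:
compound 1 `ClCc1cccc(Cn2cnc3ncnc(Cl)c32)c1`: 2180 nM
compound 2 `ClCc1ccc(Cn2cnc3nc(Cl)nc(Cl)c32)cc1`: 1900 nM

Both were tested in a functional assay on HOP-62 cells (Homo sapiens) for cytotoxicity, read by sulforhodamine B assay, with a stated time of 48 h; a lower number here means a stronger inhibitor of growth, a higher number a weaker inhibitor of growth. Within the data shown here, compound 2 has the lowest of the two numbers, but its nearest neighbour, compound 1, lies within the scatter of it, so no order between the two can be read from these figures; the two values show only that both compounds inhibit growth at similar concentrations. The two structures differ in more than one place, so nothing is said here about what any single change between them does.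

The step under review leads from compound 2 to compound 3 `ClCc1ccc(Cn2cnc3ncnc(Cl)c32)cc1`, which has not yet been tested in this assay. The difference is hydrogen in place of chloro on an aromatic carbon. Among the measured compounds shown here, with no comparable step among the measured compounds, the expectation rests only on the numbers for compound 1 and compound 2, which are close to each other. Compound 3 is expected to behave much like compound 2, with a step of a 1.3-fold higher number from compound 2 to compound 3 (0.12 log units; within the scatter) that does not clearly exceed the scatter. Compound 3 is therefore estimated at 2500 nM, in a range from 1200 nM to 5500 nM.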

Compound 3, concentration for 50% growth inhibition: 1770 nM
Estimate against measurement, compound 3: 1.4-fold (0.15 log units) above; low and high end bracket the measured number.
By their numbers in this assay, from the lowest: compounds 3, 2 and 1 (each within the scatter of the next).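

In this assay the exchange of the chloro group on the aromatic carbon between two ring nitrogen atoms for hydrogen gives a 1.1-fold lower number from compound 2 to compound 3 (0.03 log units; within the scatter) and so leaves compound 2 and compound 3 indistinguishable. Among these compounds, this is the first comparison here in which the structures differ in one place only, which compound 1 and compound 2 could not offer. It shows that, at the level of this measurement, growth inhibition in this assay does not depend on the presence of a chloro group at this position, and that hydrogen serves there as well.

The compounds shown leave open whether the position would remain as undemanding with a larger group, such as an amine or a methoxy group, in place of the chloro group or hydrogen. Among the compounds shown here, also open is what would follow from replacing the other chloro group on the same ring, the one that compound 2 and compound 3 share, with an amine or a longer chain. No measurement at hand explains the result.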